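The source may report more compounds than this note shows. Statements on the series, on what has been measured and on what is new or still open speak of the compounds shown alone.

Three compounds share one core and differ in what hangs from it. Compound 1 `COC(=O)/C=C/c1cccc(N(Cc2ccc(/C=C/c3ccccc3)cc2)C(=O)C(C)C)c1` gives 64.6 nM in an assay on isolated protein with Bile acid receptor (Homo sapiens) as the target; on this read-out higher numbers stand for an effect only at larger amounts of compound and lower numbers for an effect already at smaller amounts. Compound 3 `COC(=O)/C=C/c1cccc(N(Cc2ccc(/C=C/c3ccc(F)cc3)cc2)C(=O)C2CCCCC2)c1` gives 186 nM in this assay. Compound 2 `COC(=O)/C=C/c1cccc(N(Cc2ccc(/C=C/c3cccc(F)c3)cc2)C(=O)NC(C)C)c1` gives 468 nM in this assay, the highest of the three numbers: it lies beyond the scatter from both of the others, and so compound 2 is the one among these three whose effect needs the largest amount.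

Compound 4 `COC(=O)/C=C/c1cccc(N(Cc2ccc(-c3c(OC)cccc3OC)cc2)C(=O)NC(C)C)c1` is not yet measured. It is built from compound 2 by one change: 2,6-dimethoxyphenyl in place of 2-(3-fluorophenyl)ethenyl on an aromatic carbon. In words, the 2-(3-fluorophenyl)ethenyl group, with its one double bond outside aromatic rings, is taken away, and a 2,6-dimethoxyphenyl group, which brings two hydrogen-bond acceptors, is put on the same aromatic carbon.

Going by the values given here, no pair among the measured compounds differs in this place alone, so no measured step tells how much this change is worth. With compound 2 already at the high end of the three numbers, the expectation for compound 4 is a further, moderate rise beyond the scatter, meaning an effect only at somewhat larger amounts, although a change of this kind could also leave the number much where it is. The estimated step from compound 2 to compound 4 is a 2.1-fold higher number from compound 2 to compound 4 (0.33 log units; beyond the scatter). For compound 4 the estimate in this assay is therefore 1000 nM, with a range from 300 nM to 3500 nM.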

Compound 4, half-maximal effective concentration: 562 nM
Compound 4: middle estimate off by 1.8-fold (0.25 log units), on the high side; measured number inside the range.
By their numbers in this assay, from the lowest: compound 1; then compound 3; then compounds 2 and 4 (each within the scatter of the next).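

In this assay, going by these compounds alone, putting 2,6-dimethoxyphenyl in place of 2-(3-fluorophenyl)ethenyl gives a 1.2-fold higher number from compound 2 to compound 4 (0.08 log units; within the scatter), the first measured step at this position, on an aromatic carbon para to a large group. For this one pair, then, removing the double bond outside aromatic rings and bringing in two hydrogen-bond acceptors leaves no readable difference, even though the entering group differs clearly in makeup from the one that leaves. Nothing measured here explains why the two groups read alike.

The compounds shown leave open whether the same swap would read alike with the other groups on the amide nitrogen, those of compound 1 and compound 3, since the step is known only with the rest of compound 2 in place. They also leave open what a group of a different kind on the same aromatic carbon, such as an amine or a carboxylic acid, would do to the number, and whether each of the two methoxy groups in compound 4 has any part in its value.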